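The compounds below may be only part of what the source reports. "The series", "measured", "known", "first", "only" and "open" are said of these compounds alone.

Compound 1, `Cn1c(COc2cccc(C(=O)O)c2)nc2ccc(Oc3ccc(Cl)c(F)c3)nc21`: 25.6 10^-6 cm/s
Compound 2, `Cn1c(COc2cccc(C(=O)O)c2)nc2cnc(Oc3ccc4c(c3)CCC4)cc21`: 16.5 10^-6 cm/s
Compound 3, `Cn1c(COc2cccc(C(=O)O)c2)nc2ccc(Oc3ccccn3)cc21`: 2.2 10^-6 cm/s

These three compounds share one core and were measured in an ADME assay for permeability, using PAMPA, with a stated time of 4 h; on this read-out higher numbers stand for higher permeability and lower numbers for lower permeability. Compound 3 gives the lowest number of the three; the nearest value, that of compound 2, is higher by a margin beyond the scatter, and that of compound 1 lies higher still. Compound 4, `Cn1c(COc2cccc(C(=O)O)c2)nc2ccc(Oc3ncccc3F)cc21`, has not yet been measured in this assay. It differs from compound 3 in one place: fluoro in place of hydrogen on an aromatic carbon. Going by the values given here, no pair of measured compounds differing in just one place is available to calibrate such a change, so the expectation rests on compound 3 alone. A small upward step, at most barely beyond the scatter, is expected: a 1.8-fold higher number from compound 3 to compound 4 (0.26 log units; within the scatter). Compound 4 is thus expected to give 4 10^-6 cm/s, in a range from 1.5 10^-6 cm/s to 10 10^-6 cm/s.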

Compound 4, apparent permeability: 3.9 10^-6 cm/s
Beside the measured number, compound 4's estimate is 1.0-fold (0.01 log units) above it, and the stated range covers the measured number.
By their numbers in this assay, from the lowest: compounds 3 and 4 (each within the scatter of the next); then compounds 2 and 1 (each within the scatter of the next).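

Going by these compounds alone, this gives the first comparison of compounds differing in one place in this assay, with fluoro in place of hydrogen on an aromatic carbon two atoms from the ring nitrogen giving a 1.8-fold higher number from compound 3 to compound 4 (0.25 log units; within the scatter). At this position, then, a single fluorine leaves the read-out within the usual scatter. No supporting measurement is available to explain this result. From the compounds shown here alone, whether chloro, methyl, methoxy or an amine on this same carbon would give a step beyond the scatter remains open. So does the outcome of placing fluoro elsewhere on this ring.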